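Aryl urea series: five-membered ring swap at compound 2

The source may hold more compounds than are shown below. What is called first, only, known or untested is meant among the compounds shown, and "the series" means these compounds.

Measured so far:
Compound 1, `O=C(Nc1c(F)cc(F)cc1F)N(Cc1ccc(F)cc1)Cc1cccc(-c2cc[nH]n2)c1`: in a functional assay on a cell-free system (plasma) with sterol O-acyltransferase, Soat (Rattus norvegicus) as the target (a lower number here means that less compound is needed, a higher number that more compound is needed for the effect), compound 1 gives < 0.32 mg/kg, which is a limit of the assay.
Compound 2, `Cc1cc(C)c(NC(=O)N(Cc2cccc(-n3cccc3)c2)C2CCCCCC2)c(C)c1`: in this assay compound 2 gives 0.17 mg/kg.
Compound 3, `Cc1cc(C)c(NC(=O)N(Cc2ccc(-c3ccn(C)n3)cc2)C2CCCCCC2)c(C)c1`: in this assay compound 3 gives < 1 mg/kg, which is a limit of the assay.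

Within the data shown here, compound 2 therefore holds the only number in this assay; the other two values are limits and set no number (the limit of < 0.32 mg/kg in this assay, at which 1 of the 3 values shown sits; (the limit of < 1 mg/kg in this assay, at which 1 of the 3 values shown sits)).

Compound 4, `Cc1cc(C)c(NC(=O)N(Cc2cccc(-c3ccnn3C)c2)C2CCCCCC2)c(C)c1`, differs from compound 2 in one place: 1-methyl-1H-pyrazol-5-yl in place of 1H-pyrrol-1-yl on an aromatic carbon. Among the measured compounds shown here, no pair of measured compounds differs in just one place, so no measured step sizes this kind of change. Compound 1 and compound 3 both carry a pyrazolyl group on the six-membered aromatic ring of carbon only and both sit at limits, which is compatible with a dose near that of compound 2 but does not fix it.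

The step from compound 2 to compound 4 is expected to stay within the usual scatter or lean slightly towards more compound, as a 1.8-fold higher number from compound 2 to compound 4 (0.25 log units; within the scatter). Compound 4 is expected at 0.3 mg/kg, with a range from 0.1 mg/kg to 1 mg/kg.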

Compound 4, dose for half-maximal effect: > 1 mg/kg
Compound 4 ended at the assay's limit; the forecaster's own chance of this, stated with the estimate: 40%; at least 3.3-fold (0.52 log units) between middle value and limit.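

In this assay, among these compounds, 1-methyl-1H-pyrazol-5-yl in place of 1H-pyrrol-1-yl on this aromatic carbon gives an at least 5.8-fold higher number from compound 2 to compound 4 (0.76 log units; beyond the scatter), the first step that sizes a change at this place. The value of compound 4, > 1 mg/kg, is a limit of the assay. The exchange of one five-membered aromatic ring for another at this place is therefore not neutral in this assay, something the limits of compound 1 and compound 3 could not show.

Nothing measured in the compounds shown gives a reason for this step. From the compounds shown here alone, it remains open whether the step follows the added methyl, the second ring nitrogen or the change in ring attachment from nitrogen to carbon, and a 1-methyl-1H-pyrrol-2-yl group at the same place would bear on that question.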